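Methylsulfonyl in place of methyl: the next step

The source may hold more compounds than are shown below. What is called first, only, known or untested is meant among the compounds shown, and "the series" means these compounds.

Of the compounds shown here, three have been measured in a functional assay on HEK293 cells for antagonist activity at transient receptor potential cation channel subfamily V member 1 (Rattus norvegicus), read by calcium flux; a lower number here means a stronger inhibitor, a higher number a weaker inhibitor. Compound 1, `FC(F)(F)c1ccc(Nc2ncnc3sc(Nc4ccccc4C(F)(F)F)nc23)cc1`, gives 37 nM. Compound 2, `Clc1cccc(Cl)c1Nc1nc2c(Nc3ccccc3)ncnc2s1`, gives 170 nM. Compound 3, `Cc1ccc(Nc2ncnc3sc(Nc4c(Cl)cccc4Cl)nc23)cc1`, gives 32 nM. Among these numbers compound 3 has the lowest, but its gap to compound 1 lies within the usual scatter, and only its gap to compound 2 is beyond it. For the measured compounds named here, the one single-point step in the set is a 5.3-fold lower number from compound 2 to compound 3 (0.73 log units; beyond the scatter), a modest gain.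

Compound 4, `CS(=O)(=O)c1ccc(Nc2ncnc3sc(Nc4c(Cl)cccc4Cl)nc23)cc1`, awaits measurement. It differs from compound 3 in one place: methylsulfonyl in place of methyl on an aromatic carbon. Going by the values given here, no measured step involves a methylsulfonyl group, so the only step that speaks to this place is the one just described, which shows that the value responds to what is attached there. Among the compounds with values here, compound 1, which carries a trifluoromethyl group on that ring together with a different second aryl amine, gives a value within the scatter of compound 3; no step between them is available, so this is only a hint that a larger group than hydrogen is tolerated.

Compound 4 is therefore expected to land near 80 nM, with a range from 15 nM to 400 nM. The estimated step is a 2.5-fold higher number from compound 3 to compound 4 (0.40 log units; beyond the scatter), a small loss that may not exceed the scatter.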

Compound 4, half-maximal inhibitory concentration: 3 nM
Compound 4: the middle estimate sits 27-fold (1.43 log units) above what was measured, and the stated range ends above it.
By their numbers in this assay, from the lowest: compound 4; then compounds 3 and 1 (each within the scatter of the next); then compound 2.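

For the compounds shown here, at this place on the aromatic ring, para to a large group, the earlier compounds showed only that methyl in place of hydrogen lowers the number; an 11-fold lower number from compound 3 to compound 4 (1.03 log units; beyond the scatter) in this assay now shows that the position accepts the larger methylsulfonyl group and that the value can fall much further than methyl alone took it. Measured from the unsubstituted ring, the full change is a 57-fold lower number from compound 2 to compound 4 (1.75 log units; beyond the scatter) and exceeds a 5.3-fold lower number from compound 2 to compound 3 (0.73 log units; beyond the scatter) by a wide margin, so that across these three compounds, which differ only here, the numbers fall in the order hydrogen, methyl, methylsulfonyl. Nothing among the data shown explains why this group has so large an effect.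

Three groups at one position cannot tell whether the sulfonyl unit itself matters, so a sulfonamide, a nitrile or the longer ethylsulfonyl group remains an open test of how far the trend extends. Going by these compounds alone, the trifluoromethyl group of compound 1 offers no answer, as that compound also carries a different second aryl amine and no single-change step links it to the others.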